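Swapping Fluoro for Dimethylamino on a Benzimidazole Scaffold

The compounds below may be only part of what the source reports. "The series", "measured", "known", "first", "only" and "open" are said of these compounds alone.

Measured so far:
Compound 1, `CCCCCn1c(N)nc2cc(C)ccc21`: 4570 nM
Compound 2, `CCCCCn1c(N)nc2ccc(C)cc21`: 7210 nM
Compound 3, `CCCCCn1c(N)nc2c(F)cccc21`: "not active" (no number reported)

All three compounds share a core, seen in compound 1 `CCCCCn1c(N)nc2cc(C)ccc21`, carrying a pentyl chain and an amino group, and differ only in the small substituent on the six-membered carbon ring. In an assay on HEK293 cells for agonist activity at Toll-like receptor 8 (Homo sapiens), read by reporter gene assay (a lower number here means that less compound is needed, a higher number that more compound is needed for the effect), compound 1 gives 4570 nM and compound 2 gives 7210 nM. Compound 3 stands apart: in this assay compound 3 is reported as "not active" (no number reported), and no number exists for it, so its position on the scale cannot be placed beyond saying that it fell short of what the assay could quantify.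

Compound 4, `CCCCCn1c(N)nc2c(N(C)C)cccc21`, takes the step (dimethylamino in place of fluoro on an aromatic carbon). Among the compounds with values here, no measured pair shows what this exchange does, so the direction and size of the step are not known. Since compound 3 has no number at all, a return toward the values of compound 1 and compound 2 would count as a gain, yet there is no measured evidence for it. Compound 4 is therefore expected to give roughly 12000 nM, with a plausible range from 2500 nM to 60000 nM, and a real chance that only a limit is reported.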

Compound 4, half-maximal effective concentration: 7120 nM
Compound 4: the middle estimate sits 1.7-fold (0.23 log units) above what was measured, within the range that was stated.
By their numbers in this assay, from the lowest: compounds 1, 4 and 2 (each within the scatter of the next).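

No step can be read from compound 3 to compound 4: compound 3 is reported without a number, so the exchange of fluoro for dimethylamino has no measurable size here. Nothing available explains the result. The compounds shown leave open how much the dimethylamino group itself changes the activity, and whether this exchange would act alike on other compounds.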